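Adding a third methoxy group to compound 2

The source may report more compounds than this note shows. Statements on the series, on what has been measured and on what is new or still open speak of the compounds shown alone.

Of the compounds shown here, two of a shared core have been measured in a functional assay on HL-60 cells (Homo sapiens) for cytotoxicity, read by MTT assay, with a stated time of 72 h; on this read-out higher numbers stand for weaker inhibition and lower numbers for stronger inhibition. Compound 1 `COc1cc(Nc2nc3ccccc3nc2S(=O)(=O)c2ccccc2)cc(OC)c1OC` gives 1770 nM. Compound 2 `COc1cc(Nc2nc3ccccc3nc2S(=O)(=O)c2ccc(Br)cc2)cc(OC)c1` gives 2540 nM; it has the highest of the two numbers, and its nearest neighbour, compound 1, lies within the scatter, so the two read as alike. Compound 1 and compound 2 differ in two places, so their values show only that both sit in the same range.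

Compound 3 `COc1cc(Nc2nc3ccccc3nc2S(=O)(=O)c2ccc(Br)cc2)cc(OC)c1OC` is the next step from compound 2. The change is methoxy in place of hydrogen on an aromatic carbon. Among the measured compounds shown here, no step between measured compounds matches this one, so there is no direct guide. Compound 3 shares its three methoxy groups with compound 1, and its value in this assay is expected near that of compound 1, a step of a 1.4-fold lower number from compound 2 to compound 3 (0.15 log units; within the scatter) that stays within the scatter. Compound 3 is estimated at 1800 nM, with a range from 700 nM to 4500 nM.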

Compound 3, half-maximal inhibitory concentration: 1020 nM
Compound 3: the middle estimate sits 1.8-fold (0.25 log units) above what was measured; the range from low to high includes it.
By their numbers in this assay, from the lowest: compounds 3, 1 and 2 (each within the scatter of the next, the first and the last beyond it).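

In this assay, among the compounds shown here, methoxy in place of hydrogen, on the aromatic carbon ortho to two methoxy groups and para to a large group, gives a 2.5-fold lower number from compound 2 to compound 3 (0.40 log units; beyond the scatter) and thus the first step in this set that lies beyond the scatter, though only a modest one. The bromo change reads differently: a 1.7-fold lower number from compound 1 to compound 3 (0.24 log units; within the scatter) stays within the scatter, so bromo in place of hydrogen shows no clear effect on the value in the presence of all three methoxy groups. No independent measurement is available to explain either result.

Still open, on these data alone, is whether the methoxy step keeps its size on a compound without the bromo group. Also open, as far as these compounds go, is how this position would respond to another group, such as a hydroxyl, an ethoxy or an amine.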